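The compounds below may be only part of what the source reports. "The series", "measured", "known", "first", "only" and "open" are said of these compounds alone.

For the measured compounds named here, in a physicochemical assay for solubility, read by nephelometry, in phosphate buffer, measured as kinetic solubility, with a stated time of 30 min, at pH 6.5 (a higher number here means a more soluble compound, a lower number a less soluble compound), compound 2 `O=C(O)CNC(=O)COc1ccc([C@H]2CC[C@]3(CC2)OOC2(O3)C3CC4CC(C3)CC2C4)cc1` gives 12.5 ug/mL, the only actual number so far. Compound 3 `O=C(O)CCCOc1ccc([C@H]2CC[C@]3(CC2)OOC2(O3)C3CC4CC(C3)CC2C4)cc1`, still unmeasured, has 2-carboxyethyl in place of (carboxymethyl)carbamoyl on a saturated chain carbon bound to an oxygen on an aromatic ring. Compound 1 `O=C(O)COc1ccc([C@H]2CC[C@]3(CC2)OOC2(O3)C3CC4CC2CC(C3)C4O)cc1` also has no such carbamoyl and differs elsewhere too. Compound 1 gives < 1.6 ug/mL, which is a limit of the assay and not a number. On that one reading of compound 1 < 1.6 ug/mL, a fall beyond the usual scatter is expected in this assay. The estimate for compound 3 is 3 ug/mL, with an expected range of 1.2 ug/mL to 12 ug/mL. This estimate means an expected step of a 4.2-fold lower number from compound 2 to compound 3 (0.62 log units; beyond the scatter).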

Compound 3, solubility: < 3.1 ug/mL
Compound 3 was reported as a limit; the forecaster's own chance of this, stated with the estimate: 35%; the middle value does not contradict the limit.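

For the compounds shown here, compound 1 and compound 2 differ in more than one place, so this is the first change here that can be read on its own. In this assay, 2-carboxyethyl in place of (carboxymethyl)carbamoyl on a saturated chain carbon bound to an oxygen on an aromatic ring gives an at least 4.0-fold lower number from compound 2 to compound 3 (0.60 log units; beyond the scatter). The reading of compound 3 is a limit and not a number: the limit of < 3.1 ug/mL in this assay, at which 1 of the 3 values shown sits.

The compounds shown cannot tell whether the amide or the chain length matters more. As far as these compounds go, how an amine or a longer chain at this place would read also remains open.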